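Working notes: the step from compound 2 to compound 3

The source may hold more compounds than are shown below. What is called first, only, known or untested is meant among the compounds shown, and "the series" means these compounds.

Measured so far, in an assay on isolated protein (strain Sprague-Dawley) for inhibition of Amine oxidase [flavin-containing] A (Rattus norvegicus), read by spectrophotometry, with a stated time of 5 min, tested at 10 uM; a higher number here means more inhibition at the concentration tested (going by the name of the read-out), a lower number less inhibition:
- compound 1 `COCOc1cc(=O)oc2cc(OCc3cccc(Cl)c3)ccc12` gives 23%
- compound 2 `CC(=O)COc1cc(=O)oc2cc(OCc3cccc(Cl)c3)ccc12` gives 22%

Compound 2 stands lowest of the two numbers in this assay, but only by a margin that the measurement itself cannot resolve: compound 1 sits nearest, and the step of a number 1 percentage points lower from compound 1 to compound 2 (within the scatter) is within the scatter. On the numbers shown, compound 1 and compound 2 are indistinguishable.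

Compound 3 `O=C(O)COc1cc(=O)oc2cc(OCc3cccc(Cl)c3)ccc12` is not yet measured. Relative to compound 2 it carries the change (hydroxy in place of methyl on a carbonyl carbon), so that 2-oxopropoxy becomes carboxymethoxy on the shared core.

Among the compounds with values here, the only measured step, a number 1 percentage points lower from compound 1 to compound 2 (within the scatter), concerns a different change (acetyl in place of methoxy on a saturated chain carbon bound to an oxygen on an aromatic ring) and was within the scatter. Within the data shown here, no measured pair covers hydroxy in place of methyl on a carbonyl carbon, so nothing here argues for a shift in this assay beyond the scatter in either direction. The expected step of a number 2 percentage points lower from compound 2 to compound 3 (within the scatter) is therefore small. Compound 3 is estimated at 20%, with a range from 5% to 38%.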

Compound 3, a percentage reported as inhibition, at one concentration (the size of the read-out at that concentration, not a potency): 0%
For compound 3 the middle estimate is 20 percentage points above the measured one; the measured number lies below the stated range.
By their numbers in this assay, from the lowest: compound 3; then compounds 2 and 1 (each within the scatter of the next).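

In this assay this position on the shared core had shown no readable difference so far, but the end group attached to it is not indifferent. Hydroxy in place of methyl on a carbonyl carbon gives a number 22 percentage points lower from compound 2 to compound 3 (beyond the scatter) and thus shows that exchanging one heavy atom, turning 2-oxopropoxy into carboxymethoxy, is enough to move the read-out beyond the scatter. Carboxy in place of methoxy on the same saturated chain carbon points the same way with a number 23 percentage points lower from compound 1 to compound 3 (beyond the scatter) and so places both readable steps at the carboxymethoxy group, while no information here bears on the reason for this drop.

The compounds shown leave open whether the drop requires the free carboxylic acid, since a methyl ester or a primary amide on the same carbonyl carbon would test the hydroxy separately from the carbonyl. They also leave open whether a longer chain ending in carboxy, or an amine at the end of the chain, would behave like carboxymethoxy or like 2-oxopropoxy.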